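Swapping Chloro for Bromo on the Shared Core

This account rests on a few compounds, and the source may have more. Where it says the series, first, only, none or still open, it means among the compounds named here.

Of the compounds shown here, two sharing one core have been measured in a functional assay on CCRF-CEM cells (Homo sapiens), with a stated time of 72 h; a lower number here means a stronger inhibitor, a higher number a weaker inhibitor. Compound 1 `O=C1Nc2ccc(Cl)cc2/C1=N/NC(=S)Nc1ccc(Cl)cc1` gives 61000 nM in this assay. Compound 2 `Cc1ccc(CN2C(=O)/C(=N\NC(=S)Nc3ccc(Cl)cc3)c3cc(Cl)ccc32)cc1` carries a 4-methylbenzyl group where compound 1 carries a hydrogen on the amide-type nitrogen in the ring. In this assay compound 2 gives 18000 nM. That single change brings a 3.4-fold lower number from compound 1 to compound 2 (0.53 log units; beyond the scatter). Among the two numbers known so far, compound 2 therefore has the lowest, with compound 1 as its only neighbour.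

Compound 3 `Cc1ccc(CN2C(=O)/C(=N\NC(=S)Nc3ccc(Cl)cc3)c3cc(Br)ccc32)cc1` has not yet been measured. It differs from compound 2 in one place: bromo in place of chloro on an aromatic carbon. Among the compounds with values here, no measured step touches this position; the only step known concerns the amide-type nitrogen, so nothing measured bears directly on exchanging one halogen for another. Such an exchange is expected to give a step from compound 2 to compound 3 of a 1.2-fold lower number from compound 2 to compound 3 (0.08 log units; within the scatter) in this assay, not beyond the scatter. Compound 3 is estimated to give 15000 nM in this assay, with a range from 6000 nM to 45000 nM.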

Compound 3, half-maximal inhibitory concentration: 98000 nM
The estimate for compound 3 lay 6.5-fold (0.82 log units) below the measured number; the measured number lies above the stated range.
By their numbers in this assay, from the lowest: compound 2; then compounds 1 and 3 (each within the scatter of the next).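

The halogen on this aromatic carbon matters in this assay: bromo in place of chloro gives a 5.4-fold higher number from compound 2 to compound 3 (0.74 log units; beyond the scatter) and so makes a clear difference to the measured number. Within the data shown here, until now, the only measured change was on the amide-type nitrogen, where the 4-methylbenzyl group gave a 3.4-fold lower number from compound 1 to compound 2 (0.53 log units; beyond the scatter), so this result is the first sign that the ring position also affects the read-out, and here the number moves in the opposite direction. Chloro and bromo match in every count computed for them, including heavy atoms, hydrogen-bond donors, hydrogen-bond acceptors and net charge, so those counts do not separate the two groups, and no supporting measurement accounts for the step.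

With only two halogens shown here, it remains open how a fluoro group, a methoxy group or an amine on this same aromatic carbon would compare. As far as these compounds go, it is also open whether bromo in place of chloro would move the number in the same way with the amide hydrogen of compound 1 in place of the 4-methylbenzyl group.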